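This account rests on a few compounds, and the source may have more. Where it says the series, first, only, none or still open, it means among the compounds named here.

- Compound 1 `CC(C)[C@@H](NC(=O)OC(C)(C)C)C(=O)Nc1ccc2ncnc(Nc3ccc(F)c(Cl)c3)c2c1`: > 50000 nM
- Compound 2 `CC(C)(C)OC(=O)NCC(=O)Nc1ccc2ncnc(Nc3cccc(C(F)(F)F)c3)c2c1`: > 50000 nM

Both entries come from a functional assay on HepG2 cells (Homo sapiens) for antiproliferative activity, read by sulforhodamine B assay, with a stated time of 72 h (a higher number here means a weaker inhibitor, a lower number a stronger inhibitor), and neither is an exact number. Compound 2 reads > 50000 nM, which is a limit of the assay. Compound 1 reads > 50000 nM, which is also a limit. The evidence so far therefore comes down to one observation: the limit of > 50000 nM in this assay, at which 2 of the 2 values shown sit. Compound 2 thus stands at that limit, with no exact value to compare against.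

Compound 3 `CC(C)[C@@H](NC(=O)OC(C)(C)C)C(=O)Nc1ccc2ncnc(Nc3cccc(C(F)(F)F)c3)c2c1` is built from compound 2 by a single change: isopropyl in place of hydrogen on a saturated chain carbon bound to an amide-type nitrogen and a carbonyl carbon. In words, this is isopropyl in place of hydrogen on a saturated chain carbon bound to an amide-type nitrogen and a carbonyl carbon.

Within the data shown here, no measured step between two closely related compounds is available, so the data give no direct guide to the size of this change. The expectation rests on compound 2, whose limit is > 50000 nM. No change beyond the usual scatter is expected in this assay, and a further limit is the likely result. The expected change is a number no higher from compound 2 to compound 3 (the limit leaves the size open). For compound 3 the estimated value is 50000 nM, with an expected range from 20000 nM to 100000 nM.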

Compound 3, half-maximal inhibitory concentration: 4300 nM
Estimate against measurement, compound 3: 12-fold (1.07 log units) above; measured number outside the range, below it.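

In this assay, isopropyl in place of hydrogen on a saturated chain carbon bound to an amide-type nitrogen and a carbonyl carbon gives an at least 11-fold lower number from compound 2 to compound 3 (1.06 log units; beyond the scatter), so this chain carbon is a place where a substitution can change the result. The isopropyl group does not do this alone, since 3-(trifluoromethyl)phenyl in place of 3-chloro-4-fluorophenyl on a nitrogen on an aromatic ring gives an at least 11-fold lower number from compound 1 to compound 3 (1.06 log units; beyond the scatter), and both steps start from a limit, so they give only a minimum size. Among these compounds, an exact value appears only where isopropyl and 3-(trifluoromethyl)phenyl stand together, while each compound with just one of them remains at the same limit: the limit of > 50000 nM in this assay, at which 2 of the 3 values shown sit.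

On these data alone, whether a methyl group or a longer chain on the same carbon would serve as well as isopropyl remains open. As far as these compounds go, it is also open how a free amine in place of the tert-butoxycarbonyl-protected amine would change the number, and whether other aromatic groups on the nitrogen would pair with isopropyl in the same way.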